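A few compounds are considered here, and "the series" means these few. Any claim that something is new, unique, unknown or untested is made for them only; others in the source may bear on it.

Working notes on the series. In an ADME assay on blood (Rattus norvegicus) for metabolic stability, with a stated time of 2 h (on this read-out lower numbers stand for a less stable compound and higher numbers for a more stable compound), compound 1 `CCn1c(CNc2ccccc2)nnc1SCc1nc2cc(C)ccc2o1` is reported as "not determined" (no result reported), compound 3 `CCn1c(CNc2ccccc2)nnc1SCc1nc2cc(F)ccc2o1` is reported as "not determined" (no result reported), and compound 2 `CCn1c(CNc2ccccc2)nnc1SCc1nc2cc(C(=O)C(C)C)ccc2o1` gives 42% in this assay. Compound 3 thus stands without a number, and one further entry, compound 1, also lacks one. Compound 4 `CC/C(=N/O)c1ccc2oc(CSc3nnc(CNc4ccccc4)n3CC)nc2c1` differs from compound 3 by a group of 5 heavy atoms (3 carbon, 1 nitrogen, 1 oxygen; no ring) in place of one fluorine atom, on an aromatic carbon. Among the measured compounds shown here, no step between measured compounds exists, so neither the size nor the direction of the change in this assay from compound 3 to compound 4 can be read from the data, and a step of any size beyond the scatter remains possible. For the measured compounds named here, the only numerical anchor is compound 2 with 42%. Compound 4 is expected to give about 45% in this assay, estimated between 20% and 75%.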

Compound 4, percent of the compound remaining: 100%
The estimate for compound 4 lay 55 percentage points below the measured number, and the stated range ends below it.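

This position on the aromatic carbon tolerates a large change in read-out: two groups of equal heavy-atom count give, in this assay, a number 58 percentage points higher from compound 2 to compound 4 (beyond the scatter), so size alone does not fix the value here. Among the compounds shown here, the earlier compounds offered only one number and so could not show this sensitivity. Nothing available bears on the origin of this step. Steps from compound 1 or compound 3 to compound 4 cannot be read. Open, from the compounds shown here alone, is how an amine, a carboxylic acid or a longer chain on this aromatic carbon would behave in this assay.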